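The source may hold more compounds than are shown below. What is called first, only, known or untested is meant among the compounds shown, and "the series" means these compounds.

In a functional assay on PC-3 cells (Homo sapiens) for inhibition, read by MTT assay, with a stated time of 96 h (a lower number here means a stronger inhibitor of growth, a higher number a weaker inhibitor of growth), compound 1 `O=C(NCCCCCCSSCCCCCCNC(=O)c1cc(-c2ccncc2)n[nH]1)c1cc(-c2ccncc2)n[nH]1` gives 4740 nM, while compound 2 `O=C(OCc1ccccc1)SCCCCCCNC(=O)c1cc(-c2ccncc2)n[nH]1` gives 15400 nM. Compound 2 therefore has the higher of the two numbers, and the gap between them lies beyond the scatter. Compound 3 `CC(C)C(=O)SCCCCCCNC(=O)c1cc(-c2ccncc2)n[nH]1` has not yet been measured. It differs from compound 2 in one place: isopropyl in place of benzyloxy on a carbonyl carbon, with isopropyl in place of benzyloxy on a carbonyl carbon. Among the measured compounds shown here, no measured step between two compounds covers this change, so the expectation rests on only two values. For the measured compounds named here, the one lower number available comes from compound 1 at 4740 nM, which suggests a modest move downward in this assay rather than a rise, though this is weak evidence. The expected step is a 2.1-fold lower number from compound 2 to compound 3 (0.31 log units; beyond the scatter). For compound 3, the estimated value is 7500 nM, with an expected range from 2500 nM to 20000 nM.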

Compound 3, concentration for 50% growth inhibition: 22400 nM
Estimate against measurement, compound 3: 3.0-fold (0.48 log units) below, and the stated range ends below it.
By their numbers in this assay, from the lowest: compound 1; then compounds 2 and 3 (each within the scatter of the next).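

In this assay, putting isopropyl in place of benzyloxy on a carbonyl carbon whose other neighbour is sulfur gives a 1.5-fold higher number from compound 2 to compound 3 (0.16 log units; within the scatter). This first step at the position shows that the assay does not separate these two groups, even though the aromatic ring of benzyloxy and its hydrogen-bond acceptor leave with the change. No measurement of any property bears on this result.

The compounds shown leave open whether a different group on this carbonyl carbon, such as an amine or a longer chain, would give a step beyond the scatter. Compound 1 differs from compound 2 and compound 3 in more than one place, so its value cannot be tied to any single change.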